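This account rests on a few compounds, and the source may have more. Where it says the series, first, only, none or still open, it means among the compounds named here.

Compound 1 `Brc1cccc(CSc2nnc(-c3ccncc3)n2-c2ccccc2)c1` gives 7040 nM in a functional assay on HepG2 cells (Homo sapiens) for inhibition, read by MTT assay, with a stated time of 48 h; a lower number here means a stronger inhibitor, a higher number a weaker inhibitor. Compound 2 `O=[N+]([O-])c1ccccc1CSc1nnc(-c2ccncc2)n1-c1ccccc1` reaches only the assay limit of > 50000 nM in this assay, so no number is known for it. Compound 3 `COc1ccc(/C=N/NC(=O)CSc2nnc(-c3ccncc3)n2-c2ccccc2)cc1` gives 27100 nM in this assay, the highest of the two numbers shown; compound 1 stands nearest, with a lower number beyond the scatter. Compound 4 `O=C(CSc1nnc(-c2ccncc2)n1-c1ccccc1)N/N=C/c1cc(Br)cc(Br)c1O` is not yet measured and differs from compound 3 by 3,5-dibromo-2-hydroxyphenyl in place of 4-methoxyphenyl on a carbon with a double bond to nitrogen. Going by the values given here, the only measured step, an at least 7.1-fold higher number from compound 1 to compound 2 (0.85 log units; beyond the scatter), concerns a group on a saturated chain carbon bound to a sulfur rather than the carbon with a double bond to nitrogen changed here, so it offers no direct guide. Compound 4 is expected to show a modest step towards a lower number, a 2.3-fold lower number from compound 3 to compound 4 (0.35 log units; beyond the scatter), with an estimate of 12000 nM and a range from 3000 nM to 50000 nM.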

Compound 4, half-maximal inhibitory concentration: 7590 nM
Compound 4: middle estimate off by 1.6-fold (0.20 log units), on the high side, within the range that was stated.
By their numbers in this assay, from the lowest: compounds 1 and 4 (each within the scatter of the next); then compound 3. At a limit, above all of these: compound 2.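

Replacing 4-methoxyphenyl with 3,5-dibromo-2-hydroxyphenyl on a carbon with a double bond to nitrogen gives a 3.6-fold lower number from compound 3 to compound 4 (0.55 log units; beyond the scatter) in this assay. The group at this place therefore moves the number beyond the scatter, which the earlier step, on a saturated chain carbon bound to a sulfur, could not show. Nothing shown gives a cause for this step.

Going by these compounds alone, the single change brings in both bromine atoms and the hydroxyl, so their separate shares remain open. An unsubstituted phenyl or a 2-hydroxyphenyl without bromine would separate them, and a 4-aminophenyl would test an amine at this place.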